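The source may hold more compounds than are shown below. What is called first, only, known or untested is meant among the compounds shown, and "the series" means these compounds.

Measured so far:
compound 1 `c1ccc(CCc2ccc3c(NCCCNCc4ccco4)ccnc3c2)cc1`: 9.47
compound 2 `COc1ccc(Oc2ccc3c(NCCCNCc4cc(F)ccc4OC)ccnc3c2)cc1`: 9.28
compound 3 `FC(F)(F)c1cc(-c2ccc3c(NCCCNCc4ccco4)ccnc3c2)cc(C(F)(F)F)c1`: 9.47

All three were run in a physicochemical assay for acid dissociation. In this assay compound 2 gives 9.28, the low end of the three numbers, yet its gaps to compound 1 and to compound 3 both fall within the usual scatter, so the three compounds cannot be told apart on these values. The shared core stays; only the group on the aromatic carbon changes. Compound 4 `COc1ccc(F)cc1CNCCCNc1ccnc2cc(Cc3cc(C)cc(C)c3)ccc12` is the next member, differing from compound 2 by 3,5-dimethylbenzyl in place of 4-methoxyphenoxy on an aromatic carbon.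

Since the three measured compounds agree despite different groups at that position, no step beyond the scatter is expected for this change. The step of a number 0.12 log units higher from compound 2 to compound 4 (within the scatter) is expected to stay within the scatter. Compound 4 is estimated at 9.4, with a range from 9.1 to 9.7.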

Compound 4, acid dissociation constant: 9.47
Estimate against measurement, compound 4: 0.07 log units below, within the range that was stated.
By their numbers in this assay, from the lowest: compounds 2, 1, 3 and 4 (each within the scatter of the next).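

In this assay, going by these compounds alone, the step is a number 0.19 log units higher from compound 2 to compound 4 (within the scatter) and gives the first comparison in which only this position differs. A group with oxygen atoms and hydrogen-bond acceptors and an all-carbon group of the same heavy-atom count on this aromatic carbon therefore give values that cannot be told apart. No measurement shown accounts for this result. On these data alone, whether an amine or a carboxylic acid on this aromatic carbon would also stay within the scatter remains open.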